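Trifluoromethoxy in Place of Methyl on the Sulfonyl Aryl

The source may report more compounds than this note shows. Statements on the series, on what has been measured and on what is new or still open speak of the compounds shown alone.

Compound 1 `CC(=O)N1N=C(c2ccc(-n3cncn3)cc2)CC1c1ccc(N(C)C)cc1` gives 11% in a functional assay on HCC1806 cells (Homo sapiens) for inhibition, read by sulforhodamine B assay, tested at 10 uM; a lower number here means less inhibition, a higher number more inhibition at the concentration tested (going by the name of the read-out).
Compound 2 `CN(C)c1ccc(C2CC(c3ccc(-n4cncn4)cc3)=NN2C(=O)c2ccc(C(F)(F)F)cc2)cc1` gives 7% in this assay.
Compound 3 `Cc1ccc(S(=O)(=O)N2N=C(c3ccc(-n4cncn4)cc3)CC2c2ccc(N(C)C)cc2)cc1` gives 27.7% in this assay.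

Compound 3 stands highest of the three: the steps of a number 16.7 percentage points higher from compound 1 to compound 3 (beyond the scatter) and a number 20.7 percentage points higher from compound 2 to compound 3 (beyond the scatter) both lie beyond the scatter, while a number 4 percentage points lower from compound 1 to compound 2 (within the scatter) does not. Compound 4 `CN(C)c1ccc(C2CC(c3ccc(-n4cncn4)cc3)=NN2S(=O)(=O)c2ccc(OC(F)(F)F)cc2)cc1` differs from compound 3 by trifluoromethoxy in place of methyl on an aromatic carbon. Within the data shown here, no measured step touches this ring; the steps known all change the group on the ring nitrogen. The only faint parallel, a fluorinated aryl entering in a number 4 percentage points lower from compound 1 to compound 2 (within the scatter), stayed within the scatter. Compound 4 is therefore expected to show a step of about a number 0.3 percentage points higher from compound 3 to compound 4 (within the scatter), not beyond the scatter. Compound 4 is estimated at 28%, from 14% to 42%.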

Compound 4, a percentage reported as inhibition, at one concentration (the size of the read-out at that concentration, not a potency): 25.2%
Beside the measured number, compound 4's estimate is 2.8 percentage points above it, and the stated range covers the measured number.
By their numbers in this assay, from the lowest: compounds 2 and 1 (each within the scatter of the next); then compounds 4 and 3 (each within the scatter of the next).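

In this assay, this first change on the sulfonyl aryl gives a number 2.5 percentage points lower from compound 3 to compound 4 (within the scatter). Among these compounds, at this place, para to a large group, trifluoromethoxy with its five heavy atoms can therefore stand in for methyl without a step beyond the scatter, something the earlier steps, all at the ring nitrogen, could not show. No evidence bears on why this is so. The compounds shown leave open whether an amine or a carboxylic acid at this place would give a step beyond the scatter.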